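Swapping 2-cyanopyridin-4-yl for 5-cyanopyridin-2-yl: a stability question

The source may report more compounds than this note shows. Statements on the series, on what has been measured and on what is new or still open speak of the compounds shown alone.

Drug candidates must survive the liver's enzymes for long enough to work, so chemists test them early on liver preparations. In an ADME assay on microsomes from liver (Rattus norvegicus) for metabolic stability, read by LC-MS, with a stated time of 15 min, tested at 1 uM (a higher number here means that more of the compound is left, a lower number that less of the compound is left), compound 1 (`Cc1cc(F)cnc1N1CCN(C(=O)CCCc2cccc3ncsc23)[C@@H](C)C1`) gives 5.3% and compound 2 (`Cc1cc(F)cnc1N1CCN(C(=O)CCS(=O)(=O)c2cccc3ncsc23)[C@@H](C)C1`) gives 9.6% in the same test, two values within the usual scatter of each other.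

Compound 3 (`N#Cc1cc(N2CCN(C(=O)CCS(=O)(=O)c3cccc4ncsc34)CC2)ccn1`) has no number to start from: its result in this assay stands as "not determined" (no result reported) and so it cannot be placed beside the other two.

Compound 4 (`N#Cc1ccc(N2CCN(C(=O)CCS(=O)(=O)c3cccc4ncsc34)CC2)nc1`) has the same atoms as compound 3, joined differently. Here 5-cyanopyridin-2-yl takes the place of 2-cyanopyridin-4-yl on an amine nitrogen in a ring (5-cyanopyridin-2-yl in place of 2-cyanopyridin-4-yl on an amine nitrogen in a ring) and the rest of the molecule stays as it was.

For the measured compounds named here, with no measured step of this kind to draw on, no size of change from compound 3 can be read from the data. The best guide is compound 2 at 9.6% in this assay since it carries the same amide side chain as compound 4. A small rise from that value is possible, but nothing beyond the scatter is expected.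

For compound 4 the estimated value is 14% with an expected range from 4% to 35% in this test.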

Compound 4, percent of the compound remaining: 59%
Estimate against measurement, compound 4: 45 percentage points below; the measured number lies above the stated range.
By their numbers in this assay, from the lowest: compounds 1 and 2 (each within the scatter of the next); then compound 4.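

No step can be read from compound 3 to compound 4: in this assay compound 3 stands as "not determined" (no result reported) and only compound 4 has a number, 59%. No evidence here bears on this result. The compounds shown leave open whether replacing 2-cyanopyridin-4-yl with 5-cyanopyridin-2-yl changes how much compound remains.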